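The compounds below may be only part of what the source reports. "The series", "measured", "known", "first", "only" and "open" are said of these compounds alone.

Measured compounds in the series:
Compound 1 `C/C(=C\c1cc(-c2ccc(S(C)(=O)=O)cc2)cs1)C(N)=O`. In a functional assay on HO8910 cells (Homo sapiens) for cytotoxicity, read by CCK-8 assay, with a stated time of 24 h (a higher number here means a weaker inhibitor, a lower number a stronger inhibitor), compound 1 gives > 50000 nM, a limit of the assay.
Compound 2 `C/C(=C\c1cc(-c2ccc([N+](=O)[O-])cc2)cs1)C(N)=O`. In this assay compound 2 gives 2380 nM.
Compound 3 `C/C(=C\c1cc(-c2ccc(Cl)cc2)cs1)C(N)=O`. In this assay compound 3 gives > 50000 nM, a limit of the assay.

Compound 3 stands at the limit, not a number; it shares this with compound 1, see (the limit of > 50000 nM in this assay, at which 2 of the 3 values shown sit). The step of an at least 21-fold higher number from compound 2 to compound 3 (1.32 log units; beyond the scatter) is large; the step that the two limits leave unreadable from compound 1 to compound 3 cannot be read, both ends being limits; the step of an at least 21-fold lower number from compound 1 to compound 2 (1.32 log units; beyond the scatter) is large in the other direction. Compound 4 `C=Cc1ccc(-c2csc(/C=C(\C)C(N)=O)c2)cc1` differs from compound 3 by vinyl in place of chloro on an aromatic carbon. Within the data shown here, no measured step involves vinyl, so nothing bears directly on this change. Of the three groups tried at this position only nitro gave a readable number; chloro and methylsulfonyl both sit at the limit. The expectation for compound 4 is that it again sits at or near the limit, i.e. a number no higher from compound 3 to compound 4 (the limit leaves the size open) is expected to be no step beyond the scatter. Compound 4 is estimated at 50000 nM, with a range of 8000 nM to 200000 nM.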

Compound 4, half-maximal inhibitory concentration: > 50000 nM
Compound 4: a limit, no number; the forecaster's own chance of this, stated with the estimate: 65%; the middle value sits exactly at the limit.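

In this assay compound 4 gives > 50000 nM, a limit and not a number. Vinyl in place of nitro gives an at least 21-fold higher number from compound 2 to compound 4 (1.32 log units; beyond the scatter), so nitro remains the only group at this position with a readable value, and a third group now joins the others at the same limit: the limit of > 50000 nM in this assay, at which 3 of the 4 values shown sit. The steps among compound 1, compound 3 and compound 4 cannot be read, both ends being limits, so vinyl, chloro and methylsulfonyl cannot be ranked against one another.

As far as these compounds go, it remains open whether the readable value of compound 2 is special to nitro or would also appear with an amine or a nitrile on the same aromatic carbon. Also open is whether a methyl group on the amide nitrogen of the shared core would change the picture for any of these compounds.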